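A Repeated Exchange on the Amine Nitrogen

The source may report more compounds than this note shows. Statements on the series, on what has been measured and on what is new or still open speak of the compounds shown alone.

In a functional assay on the whole organism (stomach) with Rattus norvegicus as the target (on this read-out higher numbers stand for an effect only at larger amounts of compound and lower numbers for an effect already at smaller amounts), compound 1 `CC/N=C(\S)NCCCCCn1nc(-c2ccccc2)ccc1=O` gives 51.8 mg/kg. Compound 2 `CCC/N=C(/NC#N)NCCCCCn1nc(-c2ccccc2)ccc1=O` reaches only a limit of the assay, > 100 mg/kg. Compound 3 `CCC/N=C(/NC#N)NCCCn1nc(-c2ccccc2)ccc1=O` gives 100 mg/kg in this assay, and the difference between the core of compound 3 and the core of compound 2 is not broken down here. Between compound 2 and compound 1 the change is a group of 5 heavy atoms (3 carbon, 1 nitrogen, 1 sulfur; no ring) in place of a group of 8 heavy atoms (5 carbon, 3 nitrogen; no ring), on an amine nitrogen, and it gave an at least 1.9-fold lower number from compound 2 to compound 1 (0.28 log units; that floor lies within the scatter), a floor that exists because of the limit of > 100 mg/kg in this assay, at which 1 of the 3 values shown sits. Compound 4 `CC/N=C(\S)NCCCn1nc(-c2ccccc2)ccc1=O` is not yet measured; it differs from compound 3 by a group of 5 heavy atoms (3 carbon, 1 nitrogen, 1 sulfur; no ring) in place of a group of 8 heavy atoms (5 carbon, 3 nitrogen; no ring), on an amine nitrogen, the same change at the same place. The only ground for any expectation is the earlier step, an at least 1.9-fold lower number from compound 2 to compound 1 (0.28 log units; that floor lies within the scatter), which was itself only a floor. Compound 4 is therefore expected to give 55 mg/kg, between 30 mg/kg and 100 mg/kg, an expected step of a 1.8-fold lower number from compound 3 to compound 4 (0.26 log units; within the scatter).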

Compound 4, dose for half-maximal effect: > 100 mg/kg
Compound 4: no number, only a limit (the forecaster's own chance of this, stated with the estimate: 15%); middle value at least 1.8-fold (0.25 log units) from the limit.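

For compound 4, this assay gives only a limit, > 100 mg/kg, so the size of the step to it from compound 3 cannot be read. Going by these compounds alone, the exchange on the amine nitrogen gave a number no lower from compound 3 to compound 4 (the limit leaves the size open), but this does not show that the two cores respond differently: the same change on two cores in this assay, an at least 1.9-fold lower number (0.28 log units; that floor lies within the scatter) from compound 2 to compound 1 and a number no lower (the limit leaves the size open) from compound 3 to compound 4; the limit leaves it open whether they differ The one readable step involves a change at the saturated chain carbon rather than this exchange, with an at least 1.9-fold higher number from compound 1 to compound 4 (0.28 log units; that floor lies within the scatter).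

As far as these compounds go, how large the effect of the exchange is on either core stays open: the limit of > 100 mg/kg in this assay, at which 2 of the 4 values shown sit. Also open is how the core of compound 3 would respond to a longer chain on the amine nitrogen or to a carboxylic acid there.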